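The source may hold more compounds than are shown below. What is called first, only, known or untested is meant among the compounds shown, and "the series" means these compounds.

Compound 1 `O=C(NO)C(Cc1ccccc1)C(=O)NCc1ccc(F)cc1` is the shortest-lived of the three measured compounds: in an ADME assay on a cell-free system (plasma, Rattus norvegicus, strain Sprague-Dawley) for metabolic stability, read by LC-MS, tested at 10 uM (on this read-out lower numbers stand for a shorter-lived compound and higher numbers for a longer-lived compound), compound 1 gives 0.8 h. Compound 2 `CC(Cc1ccccc1)(C(=O)NO)C(=O)NCc1ccc(F)cc1` differs from it by methyl in place of hydrogen on a saturated chain carbon bound to two carbonyl carbons and a saturated chain carbon, and in this assay compound 2 gives 3.6 h, which is a 4.5-fold higher number from compound 1 to compound 2 (0.65 log units; beyond the scatter). Compound 3 `CC(C(=O)NO)C(=O)NCc1ccc(F)cc1` differs from compound 1 by hydrogen in place of phenyl on a saturated chain carbon, two bonds along the chain from two carbonyl carbons; in this assay compound 3 gives 33 h, the highest of the three, with a 41-fold higher number from compound 1 to compound 3 (1.62 log units; beyond the scatter) and a 9.2-fold higher number from compound 2 to compound 3 (0.96 log units; beyond the scatter). Compound 4 `CC(C)(C(=O)NO)C(=O)NCc1ccc(F)cc1` differs from compound 3 by methyl in place of hydrogen on a saturated chain carbon bound to two carbonyl carbons and a saturated chain carbon, the same change as that from compound 1 to compound 2. Because that earlier change produced a 4.5-fold higher number from compound 1 to compound 2 (0.65 log units; beyond the scatter), compound 4 is expected to show a step of similar size, a 2.4-fold higher number from compound 3 to compound 4 (0.38 log units; beyond the scatter), although this rests on a single pair. Compound 4 is therefore estimated at 80 h, between 30 h and 250 h.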

Compound 4, half-life: 19.9 h
Beside the measured number, compound 4's estimate is 4.0-fold (0.60 log units) above it; the whole stated range lies above it.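

In this assay, methyl in place of hydrogen gives a 1.7-fold lower number from compound 3 to compound 4 (0.22 log units; within the scatter), which leaves compound 3 and compound 4 within the scatter of each other, and the step does not carry over in size from the core of compound 1: the same change on two cores in this assay, a 4.5-fold higher number (0.65 log units; beyond the scatter) from compound 1 to compound 2 and a 1.7-fold lower number (0.22 log units; within the scatter) from compound 3 to compound 4, 7.5-fold (0.87 log units) apart, beyond the scatter of two such steps. Hydrogen in place of phenyl also differs between cores, giving a 5.5-fold higher number from compound 2 to compound 4 (0.74 log units; beyond the scatter) with the methyl present: the same change on two cores in this assay, a 41-fold higher number (1.62 log units; beyond the scatter) from compound 1 to compound 3 and a 5.5-fold higher number (0.74 log units; beyond the scatter) from compound 2 to compound 4, 7.5-fold (0.87 log units) apart, beyond the scatter of two such steps. Both changes therefore depend on the core that carries them in these four compounds, but the data do not show why, and they give no rule for any other core.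

The compounds shown leave open how an ethyl group would behave in place of this methyl. They also leave open what a longer chain, an amine or a carboxylic acid would do in place of the benzyl.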